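A few compounds are considered here, and "the series" means these few. Any claim that something is new, unique, unknown or untested is made for them only; others in the source may bear on it.

Three compounds have numbers in a functional assay on DU-145 cells (Homo sapiens) for cytotoxicity, read by trypan blue exclusion, with a stated time of 96 h; on this read-out lower numbers stand for stronger inhibition and higher numbers for weaker inhibition. Compound 1 `COc1ccc(/C=C/S(=O)(=O)Nc2ccc(OC)c(F)c2)cc1` gives 5000 nM; compound 2 `COc1ccc(NS(=O)(=O)/C=C/c2c(F)c(F)c(F)c(F)c2F)cc1[N+](=O)[O-]` gives 100000 nM; compound 3 `COc1cc(OC)c(/C=C/S(=O)(=O)Nc2ccc(OC)c(OP(=O)(O)O)c2)c(OC)c1` gives 40 nM, the lowest of the three, with its gap to each of the other two beyond the scatter. Compound 4 `COc1cc(OC)c(/C=C/S(=O)(=O)Nc2ccc(OC)c(NC(C(=O)O)c3ccc(F)cc3)c2)c(OC)c1` has no number yet. It differs from compound 3 in one place: a group of 12 heavy atoms (8 carbon, 1 nitrogen, 2 oxygen, 1 fluorine; one six-membered aromatic ring of carbon only) in place of a group of 5 heavy atoms (4 oxygen, 1 phosphorus; no ring), on an aromatic carbon. Among the compounds with values here, no measured pair shows this same change, so there is no direct comparison to lean on. The reading for compound 4 is expected to land above that of compound 3, since compound 3 already gives 40 nM and nothing else in the set comes near it; a step of a 13-fold higher number from compound 3 to compound 4 (1.10 log units; beyond the scatter) toward a higher number is expected. For compound 4 in this assay a value of 500 nM is estimated, between 50 nM and 5000 nM.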

Compound 4, half-maximal inhibitory concentration: 75 nM
The estimate for compound 4 lay 6.7-fold (0.82 log units) above the measured number; the range from low to high includes it.
By their numbers in this assay, from the lowest: compounds 3 and 4 (each within the scatter of the next); then compound 1; then compound 2.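

In this assay, the (carboxy(4-fluorophenyl)methyl)amino group in place of the ringless group of 5 heavy atoms gives a 1.9-fold higher number from compound 3 to compound 4 (0.27 log units; within the scatter). This position, on an aromatic carbon ortho to a methoxy group, therefore accepts a much larger group carrying a six-membered aromatic ring without leaving the scatter, something compounds 1 and 2 could not show, since neither is one change from compound 3. No measurement here explains this result.

As far as these compounds go, whether a primary amine or a hydroxyl group at this position would stay level with these two remains open. So does the contribution of the fluorine on the entering group.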